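A few compounds are considered here, and "the series" means these few. Any claim that something is new, unique, unknown or untested is made for them only; others in the source may bear on it.

The study begins with two chalcone-type compounds that carry the same coumarin-bearing triazole tail and differ in the linker length and the methoxy pattern. Compound 1, `COc1cc(/C=C/C(=O)/C=C/c2ccccc2)ccc1OCc1cn(CCCOc2cc(=O)oc3ccccc23)nn1`, and compound 2, `COc1ccc(/C=C/C(=O)/C=C/c2ccc(OCc3cn(CCCCCOc4cc(=O)oc5ccccc45)nn3)c(OC)c2)cc1`, were both tested in a functional assay on HCT-116 cells (Homo sapiens) for inhibition, read by sulforhodamine B assay, with a stated time of 48 h, tested at 50 uM; on this read-out higher numbers stand for more inhibition of growth at the one concentration tested and lower numbers for less inhibition of growth. In this assay compound 1 gives 45%, and compound 2 gives 35%. Compound 2 thus sits at the smaller of the two numbers, but the gap to compound 1 lies within the usual scatter of repeated measurements, so the two cannot be told apart on this read-out.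

Compound 3, `COc1cccc(/C=C/C(=O)/C=C/c2ccc(OCc3cn(CCCCCOc4cc(=O)oc5ccccc45)nn3)c(OC)c2)c1`, has not yet been measured in this assay. It is related to compound 2 by a single rearrangement: 3-methoxyphenyl in place of 4-methoxyphenyl on a double-bonded chain carbon bound to a double-bonded chain carbon. The two compounds contain the same atoms, only joined differently. Going by the values given here, no measured pair in this set shows what moving the methoxy group on that ring does, so there is no observed step to lean on. With nothing to suggest otherwise, the expected step of a number 3 percentage points higher from compound 2 to compound 3 (within the scatter) is estimated as none beyond the scatter. For compound 3 the estimated value is 38%, with an expected range from 18% to 58%.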

Compound 3, percent growth inhibition at one concentration: 36%
For compound 3 the middle estimate is 2 percentage points above the measured one; low and high end bracket the measured number.
By their numbers in this assay, from the lowest: compounds 2, 3 and 1 (each within the scatter of the next).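

Moving the methoxy group gives the first direct reading at this position: in this assay, 3-methoxyphenyl in place of 4-methoxyphenyl on a double-bonded chain carbon bound to a double-bonded chain carbon gives a number 1 percentage points higher from compound 2 to compound 3 (within the scatter), the only step between measured compounds that differ in one place. The two compounds contain the same atoms, and on this read-out, at the one concentration tested, they cannot be told apart, so this change of the methoxy group leaves no visible mark on growth inhibition. Nothing shown offers an explanation for this result or ties it to a property of either group.

The compounds shown leave open whether a group of another kind on this ring, such as an amine or a carboxylic acid in place of the methoxy group, would give a number beyond the scatter from those of compound 2 and compound 3. They also leave open what the linker alone contributes, or a longer chain there, since compound 1 and compound 2 differ in more than one place.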